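Oral exposure across the series: outlook for compound 4

A few compounds are considered here, and "the series" means these few. Any claim that something is new, unique, unknown or untested is made for them only; others in the source may bear on it.

Compound 1 `CCCCCOC(=O)N1CCN(C(=O)[C@H](CCC(=O)O)NC(=O)c2cc(N3CCC(C(=O)NCC)CC3)nc(-c3ccccc3)n2)CC1`: in an in vivo ADME assay on the whole organism (strain Sprague-Dawley) for pharmacokinetics, with Rattus norvegicus as the target, at a dose of 5 mg/kg by the oral route (a lower number here means that a smaller share of the oral dose reaches the circulation, a higher number that a larger share of the oral dose reaches the circulation), compound 1 gives 8%.
Compound 2 `CCCCCOC(=O)N1CCN(C(=O)[C@H](CCC(=O)O)NC(=O)c2cc(N3CCC(COC)CC3)nc(-c3ccccc3)n2)CC1`: compound 2 gives 61%.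
Compound 3 `CCCCCOC(=O)N1CCN(C(=O)[C@H](CCC(=O)O)NC(=O)c2nc(-c3ccccc3)cc(N3CCC(CN)CC3)n2)CC1`: compound 3 gives 1%.

Compound 2 stands highest of the three numbers in this assay; compound 1 and compound 3 both lie far below it, each gap beyond the scatter. Compound 4 `CCCCCOC(=O)N1CCN(C(=O)[C@H](CCC(=O)O)NC(=O)c2cc(N3CCC(CNC)CC3)nc(-c3ccccc3)n2)CC1` differs from compound 2 by methylamino in place of methoxy on a saturated chain carbon bound to a saturated ring carbon. For the measured compounds named here, one measured step bears on it: a number 53 percentage points higher from compound 1 to compound 2 (beyond the scatter), a large move for a single exchange at the saturated ring carbon. Compound 3, which carries aminomethyl on the saturated ring carbon, gives 1%, the lowest number seen. Both observations point to a large downward step. Compound 4 is therefore expected at 6%, within 1% to 22%. The expected step is a number 55 percentage points lower from compound 2 to compound 4 (beyond the scatter), beyond the scatter.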

Compound 4, oral bioavailability: 2%
Beside the measured number, compound 4's estimate is 4 percentage points above it; measured number inside the range.
By their numbers in this assay, from the lowest: compounds 3, 4 and 1 (each within the scatter of the next); then compound 2.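

In this assay, methylamino in place of methoxy on a saturated chain carbon bound to a saturated ring carbon gives a number 59 percentage points lower from compound 2 to compound 4 (beyond the scatter), although both groups hold the same number of heavy atoms. The other exchange gives a number 6 percentage points lower from compound 1 to compound 4 (within the scatter), so among these exchanges only the methoxymethyl of compound 2 stands apart. Nothing at hand accounts for the drop. From the compounds shown here alone, whether hydroxymethyl or dimethylaminomethyl at this place would stay with compound 2 or with compound 4 remains open.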